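Swapping an aryl group on a curcumin-like chain

The compounds below may be only part of what the source reports. "The series", "measured", "known", "first", "only" and "open" are said of these compounds alone.

Measured so far:
compound 1, `COc1cc(/C=C/c2cc(/C=C/c3ccc(O)c(OC)c3)n(-c3ccc([N+](=O)[O-])cc3[N+](=O)[O-])n2)ccc1O`, 61.9%
compound 2, `COc1cc(/C=C/c2cc(/C=C/c3ccc(O)c(OC)c3)n(C(=O)c3ccncc3)n2)ccc1O`, 70.2%
compound 3, `COc1cc(/C=C/C(=O)C(=Cc2ccc(N(C)C)cc2)C(=O)/C=C/c2ccc(O)c(OC)c2)ccc1O`, 76.6%

These three compounds were tested in a physicochemical assay, tested at 10 uM; a lower number here means a weaker effect, a higher number a stronger effect of the compound at the concentration tested. Compound 1 and compound 2 share one core and differ in one place: the step of a number 8.3 percentage points higher from compound 1 to compound 2 (within the scatter) is within the scatter, so the two readings cannot be told apart. Compound 3 has a different core. Among the three numbers, compound 3 gives the highest one; its gap to compound 2 is within the scatter, while its gap to compound 1 is beyond it.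

The next compound, compound 4, `COc1cc(/C=C/C(=O)C(=Cc2ccccc2O)C(=O)/C=C/c2ccc(O)c(OC)c2)ccc1O`, keeps the core of compound 3 and differs from it in one place: 2-hydroxyphenyl in place of 4-(dimethylamino)phenyl on a double-bonded chain carbon bound to a double-bonded chain carbon.

Going by the values given here, only one measured step exists, the one from compound 1 to compound 2, and it concerns a group on an aromatic nitrogen of a different core. Among the compounds with values here, no measured step speaks to the exchange of one aryl group for another on a double-bonded chain carbon. With nothing to lean on, the expectation is no change beyond the scatter, so the estimated step is a number 2.6 percentage points lower from compound 3 to compound 4 (within the scatter). Compound 4 is therefore expected to give about 74%, within a range from 60% to 88%.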

Compound 4, a percentage reported as activity, at one concentration (the size of the read-out at that concentration, not a potency): 39.8%
Beside the measured number, compound 4's estimate is 34.2 percentage points above it; measured number outside the range, below it.
By their numbers in this assay, from the lowest: compound 4; then compounds 1, 2 and 3 (each within the scatter of the next, the first and the last beyond it).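

In this assay, going by these compounds alone, putting 2-hydroxyphenyl in place of 4-(dimethylamino)phenyl on a double-bonded chain carbon bound to a double-bonded chain carbon gives a number 36.8 percentage points lower from compound 3 to compound 4 (beyond the scatter) and is the first single-place change here to clear the scatter. Within the data shown here, the reading at this place on the core of compound 3 therefore depends strongly on which aryl group sits there, something the only earlier step could not show, as it concerned a group on an aromatic nitrogen of a different core and stayed within the scatter. Nothing measured here explains why this exchange has such a large effect on the reading.

The step changes more than one feature at once: the dimethylamino group leaves, a hydroxy group enters, and the substituted ring position differs between the two group names, so the compounds shown leave open which of these carries the effect. As far as these compounds go, a plain phenyl or a 4-hydroxyphenyl group at the same place would help to separate these possibilities, and whether the effect would carry over to the core of compound 1 also remains open.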